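Methoxy for fluoro on the cinnamide ring

A few compounds are considered here, and "the series" means these few. Any claim that something is new, unique, unknown or untested is made for them only; others in the source may bear on it.

Measured compounds:
compound 1 `COc1ccc(/C=C/C(=O)Nc2nnc(-c3ccc(Br)cc3)s2)cc1`, 1.04 ug/mL
compound 2 `O=C(/C=C/c1ccccc1)Nc1nnc(-c2ccccc2)s1`, 1.75 ug/mL
compound 3 `O=C(/C=C/c1ccc(F)cc1)Nc1nnc(-c2ccccc2)s1`, 1.82 ug/mL

In a functional assay on A549 cells (Homo sapiens) for antiproliferative activity, read by MTT assay, with a stated time of 48 h (on this read-out higher numbers stand for weaker inhibition and lower numbers for stronger inhibition), compound 3 gives the highest of the three numbers, though its gaps to compound 2 and to compound 1 both lie within the scatter. Compound 4 `COc1ccc(/C=C/C(=O)Nc2nnc(-c3ccccc3)s2)cc1` differs from compound 3 by methoxy in place of fluoro on an aromatic carbon. Among the compounds with values here, the only measured step that touches this ring, a 1.0-fold higher number from compound 2 to compound 3 (0.02 log units; within the scatter), was flat. Compound 1, which also carries the methoxy group but a different group on the other ring, gives 1.04 ug/mL, a number within the scatter of compound 3. Within the data shown here, no step therefore points beyond the scatter, and compound 4 is expected to show a 1.3-fold lower number from compound 3 to compound 4 (0.11 log units; within the scatter). Compound 4 is estimated at 1.4 ug/mL, within 0.7 ug/mL to 2.8 ug/mL.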

Compound 4, half-maximal inhibitory concentration: 0.76 ug/mL
Beside the measured number, compound 4's estimate is 1.8-fold (0.27 log units) above it; measured number inside the range.
By their numbers in this assay, from the lowest: compounds 4, 1, 2 and 3 (each within the scatter of the next, the first and the last beyond it).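

At this position, the change from 4-fluorophenyl to 4-methoxyphenyl moves the number beyond the scatter (a 2.4-fold lower number from compound 3 to compound 4 (0.38 log units; beyond the scatter)) in this assay. Methoxy in place of hydrogen does the same (a 2.3-fold lower number from compound 2 to compound 4 (0.36 log units; beyond the scatter)), so methoxy separates from both fluoro and hydrogen, while replacing bromo with hydrogen on the other ring stays within the scatter (a 1.4-fold lower number from compound 1 to compound 4 (0.14 log units; within the scatter)). Nothing measured here explains the methoxy step. From the compounds shown here alone, whether ethoxy, hydroxy or an amine at this position would behave like methoxy remains open. So does whether fluoro and hydrogen would also sit apart from methoxy with bromo on the other ring.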